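Amide ring size step in the series

This account rests on a few compounds, and the source may have more. Where it says the series, first, only, none or still open, it means among the compounds named here.

Two compounds have numbers in an ADME assay on microsomes from liver (Homo sapiens) for metabolic stability, read by LC-MS, using NADPH, with a stated time of 45 min, tested at 0.5 uM; on this read-out lower numbers stand for slow clearance and higher numbers for fast clearance. Compound 1 `CS(=O)(=O)C1CCN(C(=O)CCSc2nc3cc(Cl)ccc3o2)CC1` gives 0.5 mL/min/g in this assay. Compound 2 `O=C(CCSc1nc2cc(Cl)ccc2o1)N1CCC1` gives 3.7 mL/min/g in this assay, which is the highest of the two numbers; its gap to compound 1 lies beyond the scatter. Compound 3 `O=C(CCSc1nc2cc(Cl)ccc2o1)N1CCCCC1` has not yet been measured. It differs from compound 2 in one place: piperidin-1-yl in place of azetidin-1-yl on a carbonyl carbon. Among the compounds with values here, no step between measured compounds covers this exact exchange, so the direction rests on where compound 2 stands, already at the high end of the two numbers. Within the data shown here, compound 1, the only other compound, also carries a piperidin-1-yl group, but one that bears a further group, so it does not read directly onto compound 3. The step from compound 2 to compound 3 is expected to be modest and upward, a 1.6-fold higher number from compound 2 to compound 3 (0.21 log units; within the scatter), with a spread wider than the scatter allowed for. Compound 3 is estimated at 6 mL/min/g in this assay, within 2.5 mL/min/g to 14 mL/min/g.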

Compound 3, intrinsic clearance in a liver preparation (reported as CLH), per the amount of preparation that the assay uses: 10.7 mL/min/g
Beside the measured number, compound 3's estimate is 1.8-fold (0.25 log units) below it; the range from low to high includes it.
By their numbers in this assay, from the lowest: compound 1; then compound 2; then compound 3.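

In this assay, the amide ring on the carbonyl carbon now has a read with nothing else changed: a 2.9-fold higher number from compound 2 to compound 3 (0.46 log units; beyond the scatter), with piperidin-1-yl in place of azetidin-1-yl, so this exchange alone moves the number beyond the scatter. A second single change reads on the piperidine ring itself: a 21-fold higher number from compound 1 to compound 3 (1.33 log units; beyond the scatter), with hydrogen in place of methylsulfonyl on a saturated ring carbon, which places the unsubstituted piperidin-1-yl amide highest of the three and its methylsulfonyl-bearing counterpart lowest. Nothing available gives a reason for either step.

On these data alone, with only the four-membered and six-membered rings compared without a further group, it remains open whether the number rises steadily with ring size, and pyrrolidin-1-yl or morpholin-4-yl on the carbonyl carbon would test this. As far as these compounds go, it is also open whether the lower number is particular to methylsulfonyl or also holds for a hydroxyl, a carboxylic acid or an amine on a saturated ring carbon, and whether methylsulfonyl would act similarly on a ring other than piperidine.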